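Urea substituent swap: 2-fluorophenyl to isopropyl

A few compounds are considered here, and "the series" means these few. Any claim that something is new, unique, unknown or untested is made for them only; others in the source may bear on it.

Measured so far in a functional assay on cells (Neutrophil, Homo sapiens) for inhibition, with a stated time of 10 min; a lower number here means a stronger inhibitor, a higher number a weaker inhibitor:
- compound 1 `CCOC(=O)c1cnn(CC(O)CC)c1NC(=O)Nc1cccc2ccccc12` gives 9.6 nM
- compound 2 `CCOC(=O)c1cnn(CC(O)CC)c1NC(=O)Nc1ccccc1F` gives 0.0016 nM
- compound 3 `CCOC(=O)c1cnn(CC(C)O)c1NC(=O)Nc1cccc(F)c1` gives 0.0007 nM

Of these three numbers, compound 2 holds the second highest. Compound 3 lies lower, and compound 1 lies far higher, both by margins beyond the scatter. The next compound to be tested is compound 4 `CCOC(=O)c1cnn(CC(O)CC)c1NC(=O)NC(C)C`, which has isopropyl in place of 2-fluorophenyl on an amide-type nitrogen.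

Among the compounds with values here, no measured pair isolates this change, and every compound measured so far carries an aromatic ring on that nitrogen. The expectation therefore rests on the spread of the values alone. Compound 2 stands at 0.0016 nM, whereas compound 1 reaches 9.6 nM, so a change at this nitrogen may plausibly move the number a long way. A large step towards weaker inhibition is expected in this assay, well beyond the scatter, though its size is poorly constrained. The expected change is a 310-fold higher number from compound 2 to compound 4 (2.49 log units; beyond the scatter), a higher number. For compound 4 the estimated value is 0.5 nM (expected range 0.01 nM to 20 nM).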

Compound 4, half-maximal inhibitory concentration: 0.0042 nM
Compound 4: middle estimate off by 120-fold (2.08 log units), on the high side, outside the stated range (below it).
By their numbers in this assay, from the lowest: compound 3; then compound 2; then compound 4; then compound 1.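

In this assay the replacement of 2-fluorophenyl by isopropyl on the amide-type nitrogen gives a 2.6-fold higher number from compound 2 to compound 4 (0.42 log units; beyond the scatter) as a modest step, though one beyond the scatter. An aromatic ring on this nitrogen is therefore not required for strong inhibition in this pair: compound 4, with no ring and fewer heavy atoms, gives 0.0042 nM in the same range as its aromatic partner, whereas compound 1, which keeps an aromatic group at this place, gives 9.6 nM and lies much higher. The position thus tolerates a small branched alkyl group as well as a small aromatic one, and the large aromatic group of compound 1 is the outlier among the compounds that share this side chain, with no measured property on hand that bears on the result.

Open, from the compounds shown here alone, is how far this tolerance extends on the nitrogen, for instance to a cyclopropyl group, a tert-butyl group, a longer alkyl chain or a chain ending in an amine or a carboxylic acid. Also open, going by these compounds, is how isopropyl behaves alongside the other alcohol side chain carried by compound 3, which differs from compound 4 in more than one place and so gives no direct comparison.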